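Same Substituent Swap Repeated on a Second Core

A few compounds are considered here, and "the series" means these few. Any claim that something is new, unique, unknown or untested is made for them only; others in the source may bear on it.

Of the compounds shown here, three built on one shared core have been tested in a functional assay on HL-60 cells (Homo sapiens) for cytotoxicity, read by MTT assay, with a stated time of 72 h; a lower number here means a stronger inhibitor, a higher number a weaker inhibitor. Compound 1 `COc1ccc(S(=O)(=O)c2nc3ccccc3nc2Nc2cc(OC)cc(OC)c2)cc1` gives 1710 nM. Compound 2 `COc1ccc(S(=O)(=O)c2nc3ccccc3nc2Nc2ccc(N)cc2)cc1` gives 710 nM in this assay, and compound 3 `COc1cc(Nc2nc3ccccc3nc2S(=O)(=O)c2ccc(F)cc2)cc(OC)c1` gives 2360 nM in this assay.

Compound 2 differs from compound 1 by a single change, (4-aminophenyl in place of 3,5-dimethoxyphenyl on a nitrogen on an aromatic ring), and this change brings a 2.4-fold lower number from compound 1 to compound 2 (0.38 log units; beyond the scatter). Compound 3 differs from compound 1 only in the core region, (fluoro in place of methoxy on an aromatic carbon), which gives a 1.4-fold higher number from compound 1 to compound 3 (0.14 log units; within the scatter).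

Compound 4 `Nc1ccc(Nc2nc3ccccc3nc2S(=O)(=O)c2ccc(F)cc2)cc1` has not yet been measured. It stands to compound 3 as compound 2 stands to compound 1: the difference is 4-aminophenyl in place of 3,5-dimethoxyphenyl on a nitrogen on an aromatic ring, and the place is described in the same words in both cases, so this is the same change made on the second core. For the measured compounds named here, only one earlier instance of this change exists, so whether its size carries over is unknown, and the simplest expectation is that it does. For compound 4 the step is estimated to be a 2.4-fold lower number from compound 3 to compound 4 (0.38 log units; beyond the scatter) in this assay, because the earlier instance gave a 2.4-fold lower number from compound 1 to compound 2 (0.38 log units; beyond the scatter). Compound 4 is thus expected to give about 980 nM in this assay, most likely between 450 nM and 2100 nM.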

Compound 4, half-maximal inhibitory concentration: 1620 nM
Estimate against measurement, compound 4: 1.7-fold (0.22 log units) below; low and high end bracket the measured number.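

In this assay, the swap to 4-aminophenyl on the second core gives a 1.5-fold lower number from compound 3 to compound 4 (0.16 log units; within the scatter), a step too small to read by itself, yet it does not differ measurably from the step on the first core: the same change on two cores in this assay, a 2.4-fold lower number (0.38 log units; beyond the scatter) from compound 1 to compound 2 and a 1.5-fold lower number (0.16 log units; within the scatter) from compound 3 to compound 4, 1.7-fold (0.22 log units) apart, within the scatter of two such steps. The swap of methoxy to fluoro, read on the compounds that carry 4-aminophenyl, gives a 2.3-fold higher number from compound 2 to compound 4 (0.36 log units; beyond the scatter), and this too agrees with its earlier instance: the same change on two cores in this assay, a 1.4-fold higher number (0.14 log units; within the scatter) from compound 1 to compound 3 and a 2.3-fold higher number (0.36 log units; beyond the scatter) from compound 2 to compound 4, 1.7-fold (0.22 log units) apart, within the scatter of two such steps. Each change therefore carried over from one core to the other as far as these four compounds can tell, but a single pair of steps per change shows only that no difference stands out from the scatter, not that the sizes are truly equal, and it gives no reason for either step.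

The compounds shown leave open whether the same agreement would hold for other groups, such as a plain phenyl on the nitrogen or chloro on the aromatic carbon. They also leave open whether these steps would look alike on a third core.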